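Three limits on one core, and an untested chain change

The source may report more compounds than this note shows. Statements on the series, on what has been measured and on what is new or still open speak of the compounds shown alone.

compound 1 `c1cncc(CN(CCCCN(C[C@H]2Cc3ccccc3CN2)[C@H]2CCCc3cccnc32)Cc2cccnc2)c1`: > 30000 nM in a functional assay on cells for agonist activity at C-X-C chemokine receptor type 4 (Homo sapiens), read by fluorescence and calcium flux, with a stated time of 90 s; a lower number here means that less compound is needed, a higher number that more compound is needed for the effect
compound 2 `c1ccc2c(c1)CN[C@@H](CN(CCCCNCC1CCNCC1)[C@H]1CCCc3cccnc31)C2`: > 30000 nM
compound 3 `FC1(F)CCC(NCc2ccc(CN(C[C@H]3Cc4ccccc4CN3)[C@H]3CCCc4cccnc43)cc2)CC1`: > 30000 nM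

Each of these three values is a limit of the assay, not a number. Compound 2 therefore stands nowhere distinct on the numbers shown: it sits where every measured compound sits, at the limit of > 30000 nM in this assay, at which 3 of the 3 values shown sit. Compound 4 `C(=C/CN(C[C@H]1Cc2ccccc2CN1)[C@H]1CCCc2cccnc21)\CNCC1CCOCC1` differs from compound 2 by a group of 11 heavy atoms (9 carbon, 1 nitrogen, 1 oxygen; one six-membered non-aromatic ring with 1 hetero atom) in place of a group of 11 heavy atoms (9 carbon, 2 nitrogen; one six-membered non-aromatic ring with 1 hetero atom), on a saturated chain carbon bound to an amine nitrogen. Among the compounds with values here, no measured pair carries this change, so its size cannot be read from any step; with all three values resting at the same limit, no step beyond the scatter in either direction is expected. Compound 4 is estimated at 30000 nM, within a range of 10000 nM to 100000 nM, most likely reported again as a limit. The expected step of a number no higher from compound 2 to compound 4 (the limit leaves the size open) is none beyond the scatter.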

Compound 4, half-maximal effective concentration: > 30000 nM
Compound 4: a limit, no number; the forecaster's own chance of this, stated with the estimate: 85%; the middle value lies on the limit itself.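

No step can be read from compound 2 to compound 4, because both values are limits of the assay: the limit of > 30000 nM in this assay, at which 4 of the 4 values shown sit.

The compounds shown leave open what concentration, if any, gives the effect for compound 2 or compound 4, and what the exchange of groups does to it.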